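From Methyl to Methoxy on an Aromatic Ring

This account rests on a few compounds, and the source may have more. Where it says the series, first, only, none or still open, it means among the compounds named here.

In a functional assay on Jurkat cells (Homo sapiens) for inhibition, read by CCK-8 assay, with a stated time of 48 h (on this read-out lower numbers stand for stronger inhibition of growth and higher numbers for weaker inhibition of growth), compound 3 (`Cc1cccc(Nc2nc(Nc3ccc(N4CCN(C)CC4)cn3)ncc2Cl)c1`) gives 15300 nM and holds the lowest number in this small set. Compound 2 (`COc1cccc(CNc2nc(Nc3ccc(N4CCN(C)CC4)cn3)ncc2Cl)c1`) gives 73400 nM in the same read-out. Compound 1 (`CN1CCN(c2ccc(Nc3ncc(Cl)c(NCc4ccc(F)cc4)n3)nc2)CC1`) reaches only a limit of this assay with > 100000 nM as its entry.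

Compound 4 (`COc1cccc(Nc2nc(Nc3ccc(N4CCN(C)CC4)cn3)ncc2Cl)c1`) departs from compound 3 in one place, with methoxy in place of methyl on an aromatic carbon. Going by the values given here, no measured step makes this exact swap, so the evidence is indirect. Compound 2 carries a 3-methoxybenzyl group, and the step to the 3-methylphenyl group in compound 3 is a 4.8-fold lower number from compound 2 to compound 3 (0.68 log units; beyond the scatter) and changes more than the ring substituent. The step of an at least 6.5-fold lower number from compound 1 to compound 3 (0.81 log units; beyond the scatter) has the same limitation. The closest comparison of ring substituents alone is 3-methoxyphenyl in place of 4-fluorophenyl, and there the step of an at least 1.3-fold lower number from compound 1 to compound 2 (0.13 log units; that floor lies within the scatter) rests on a limit and shows no firm size.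

The swap is therefore expected to matter little. The estimated step is a 1.3-fold higher number from compound 3 to compound 4 (0.12 log units; within the scatter) and would stay within the scatter or lean slightly toward higher numbers in this assay on this reading. Compound 4 is estimated at 20000 nM with an expected range of 7000 nM to 55000 nM in this read-out.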

Compound 4, concentration for 50% growth inhibition: 15800 nM
The estimate for compound 4 lay 1.3-fold (0.10 log units) above the measured number; measured number inside the range.
By their numbers in this assay, from the lowest: compounds 3 and 4 (each within the scatter of the next); then compound 2. At a limit, above all of these: compound 1.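

Going by these compounds alone, the first direct reading of this swap in this assay is a 1.0-fold higher number from compound 3 to compound 4 (0.01 log units; within the scatter), so at this aromatic carbon, meta to a large group, methyl and methoxy read alike, even though methoxy brings a hydrogen-bond acceptor that methyl lacks. The earlier gap between compound 2 and compound 3 mixed two differences, whereas with the 3-methoxy ring held constant, the change from 3-methoxybenzyl to 3-methoxyphenyl on the nitrogen stands alone, giving a 4.6-fold lower number from compound 2 to compound 4 (0.67 log units; beyond the scatter), and the change from 4-fluorobenzyl gives an at least 6.3-fold lower number from compound 1 to compound 4 (0.80 log units; beyond the scatter), which points the same way but only as a floor. Compound 1 stands at a limit of the assay and not at a number: the limit of > 100000 nM in this assay, at which 1 of the 4 values shown sits.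

The compounds shown leave open whether an amine or a carboxylic acid on this same aromatic carbon would read like methyl and methoxy, or whether this place tolerates only such small groups. They also leave open how a longer chain between the nitrogen and the ring would read, given that only the directly bound phenyl and the benzyl groups appear here.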